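The source may report more compounds than this note shows. Statements on the series, on what has been measured and on what is new or still open speak of the compounds shown alone.

Three compounds that share one core were examined in an ADME assay on a cell-free system (plasma, Rattus norvegicus) for metabolic stability, read by LC-MS, with a stated time of 60 min, at 37 degrees C, tested at 50 uM; a higher number here means that more of the compound is left, a lower number that less of the compound is left. Compound 1 `CCOC(=O)C1=C(S[C@@H]2CN[C@H](C(=O)Nc3cccc(C(=O)OCC)c3)C2)[C@H](C)[C@@H]2[C@@H]([C@@H](C)OC(=O)CC)C(=O)N12` gives 0% in this assay. Compound 2 `CC(C)OC(=O)C1=C(S[C@@H]2CN[C@H](C(=O)Nc3cccc(C(=O)OC(C)C)c3)C2)[C@H](C)[C@@H]2[C@@H]([C@@H](C)O)C(=O)N12` gives 0%, and compound 3 `C[C@@H](O)[C@H]1C(=O)N2C3=C(S[C@@H]4CN[C@@H](C4)C(=O)Nc4cccc(c4)C(=O)OCCCOC3=O)[C@H](C)[C@H]12` gives 0%; compound 1 is level with both at the digits shown, so nothing among the three separates in this assay. Compound 4 `CCOC(=O)C1=C(S[C@@H]2CN[C@H](C(=O)Nc3cccc(C(=O)OCC)c3)C2)[C@H](C)[C@@H]2[C@@H]([C@@H](C)OC(C)=O)C(=O)N12` has not been measured. It differs from compound 1 in one place: hydrogen in place of methyl on a saturated chain carbon bound to a carbonyl carbon. Going by the values given here, no measured pair differs in a single place, so the size of such a change cannot be read from the data. Because compound 1 gives 0%, compound 4 is expected to show no step beyond the scatter, no change at the digits printed from compound 1 to compound 4 (within the scatter), with an estimated value of 0% in the range 0% to 8%.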

Compound 4, percent of the compound remaining: 0%
Beside the measured number, compound 4's estimate shows no gap at the digits printed, within the range that was stated.
By their numbers in this assay, from the lowest: compounds 1, 2, 3 and 4 (each within the scatter of the next).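

In this assay, cutting propanoyloxy back to acetoxy gives the first step in one place among these compounds: no change at the digits printed from compound 1 to compound 4 (within the scatter). Since compound 4 gives 0%, this position shows no measurable response to the change, but a read-out with none of the compound left cannot reveal smaller differences in how fast each compound disappears. Nothing available explains this result.

Still open, from the compounds shown here alone, is whether another group at this position, such as an amine or a butanoyloxy chain, would leave any compound remaining. Shorter incubation times could separate these compounds, but the values shown cannot say so.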